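Thiophen-3-yl in place of pyridin-4-yl: expected cytotoxicity

The source may report more compounds than this note shows. Statements on the series, on what has been measured and on what is new or still open speak of the compounds shown alone.

Measured compounds:
compound 1 `Oc1ccc(-c2cc(-c3cccs3)nc(-c3ccccc3Cl)c2)cc1` gives 5430 nM
compound 2 `Oc1ccc(-c2cc(-c3ccncc3)nc(-c3ccccc3Cl)c2)cc1` gives "not determined" (no result reported)

Compound 2 `Oc1ccc(-c2cc(-c3ccncc3)nc(-c3ccccc3Cl)c2)cc1` stands without a number: in a functional assay on HCT-15 cells (Homo sapiens) for cytotoxicity, read by CCK-8 assay and cell counting, with a stated time of 2 days (a lower number here means a stronger inhibitor, a higher number a weaker inhibitor), compound 2 gives "not determined" (no result reported), so no single value can be placed against it. The only figure in this small set belongs to compound 1, which in this assay gives 5430 nM, a weak inhibition.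

Compound 3 `Oc1ccc(-c2cc(-c3ccsc3)nc(-c3ccccc3Cl)c2)cc1` differs from compound 2 by thiophen-3-yl in place of pyridin-4-yl on an aromatic carbon. Among the measured compounds shown here, since compound 2 carries no value, no step between them can be stated in this assay, and the size and direction of the change remain open. For the measured compounds named here, with no measured pair on which to rest, the expectation for compound 3 is drawn from the one available number, that of compound 1, and is therefore held loosely.

Compound 3 is expected to give about 5000 nM in this assay, with a range from 1500 nM to 16000 nM.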

Compound 3, half-maximal inhibitory concentration: 5830 nM
For compound 3 the middle estimate is 1.2-fold (0.07 log units) below the measured one, within the range that was stated.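

In this assay, thiophen-3-yl in place of thiophen-2-yl on the aromatic carbon next to the ring nitrogen gives a 1.1-fold higher number from compound 1 to compound 3 (0.03 log units; within the scatter) and so leaves the read-out unchanged: at this position, the point at which the thiophene ring is attached makes no difference that this assay can resolve. The step from compound 2 to compound 3 cannot be read, so the swap of pyridin-4-yl for a thiophene remains without a measured size or direction. No measurement is at hand to explain the result.

The compounds shown leave open whether a group other than these aromatic rings, such as an open-chain amine, a carboxylic acid or a plain phenyl ring, would shift the value at this position. They also leave open how changes to the 2-chlorophenyl or 4-hydroxyphenyl groups would act, since both stay the same throughout.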